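Working notes on a substituent exchange at the pyridine

The source may hold more compounds than are shown below. What is called first, only, known or untested is meant among the compounds shown, and "the series" means these compounds.

Measured so far:
compound 1 `C[C@@H](NS(C)(=O)=O)c1cncc(N2C(=O)c3ccc(Cl)cc3C2(C)C)c1` — 8 nM
compound 2 `CC1c2cc(Cl)ccc2C(=O)N1c1cccnc1` — 123 nM

In an assay on cells for inhibition of cytochrome P450 11B2, mitochondrial (Homo sapiens), read by HTRF (a lower number here means a stronger inhibitor, a higher number a weaker inhibitor), compound 1 gives 8 nM, the lowest of the two numbers; compound 2 gives 123 nM, and the gap between them lies beyond the scatter. Compound 3 `CC(=O)N1CCN(c2cncc(N3C(=O)c4ccc(Cl)cc4C3(C)C)c2)CC1` is not yet measured. It differs from compound 1 by a group of 9 heavy atoms (6 carbon, 2 nitrogen, 1 oxygen; one six-membered non-aromatic ring with 2 hetero atoms) in place of a group of 7 heavy atoms (3 carbon, 1 nitrogen, 2 oxygen, 1 sulfur; no ring), on an aromatic carbon. For the measured compounds named here, no measured pair shows this change, so the direction rests on nothing firmer than the two values at hand. A small loss in this assay is expected, not far beyond the scatter. Compound 3 is expected to give 25 nM, with a range from 6 nM to 100 nM. The estimated step is a 3.1-fold higher number from compound 1 to compound 3 (0.49 log units; beyond the scatter).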

Compound 3, half-maximal inhibitory concentration: 9 nM
Compound 3: the middle estimate sits 2.8-fold (0.44 log units) above what was measured; the range from low to high includes it.
By their numbers in this assay, from the lowest: compounds 1 and 3 (each within the scatter of the next); then compound 2.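

In this assay, replacing the open chain of compound 1 with 4-acetylpiperazin-1-yl gives a step of (a 1.1-fold higher number from compound 1 to compound 3 (0.05 log units; within the scatter)). At this aromatic carbon, two atoms from the ring nitrogen, a six-membered non-aromatic ring can therefore stand in place of the chain, and in this pair neither the defined stereocentre nor the hydrogen-bond donor of the chain is needed to keep the value. No available evidence explains this match.

Still open, as far as these compounds go, is whether a free piperazine, a simple amine or a carboxylic acid at this carbon would hold the value, and whether the acetyl group of compound 3 contributes to it.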